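A Nitrile Replaces Chlorine on a Shared Core

The source may hold more compounds than are shown below. What is called first, only, known or untested is meant among the compounds shown, and "the series" means these compounds.

Compound 2 `C=CC(=O)N1C(=O)CC(c2cccc(Cl)c2)Sc2ccccc21` sits at the low end of three figures in a functional assay on MOLT-4 cells (Homo sapiens) for cytotoxicity, read by CCK-8 assay, with a stated time of 24 h (on this read-out higher numbers stand for weaker inhibition and lower numbers for stronger inhibition), with 77500 nM, yet compound 1 `C=CC(=O)N1C(=O)CC(c2ccc([N+](=O)[O-])cc2)Sc2ccccc21` with 91500 nM and compound 3 `C=CC(=O)N1C(=O)CC(c2ccc(-c3ccccc3)cc2)Sc2ccccc21` with 97500 nM both lie within the scatter of it. Going by the values given here, the single measured step, a 1.1-fold higher number from compound 1 to compound 3 (0.03 log units; within the scatter), stays within the scatter too. Compound 4 `C=CC(=O)N1C(=O)CC(c2ccc(C#N)cc2)Sc2ccccc21` differs from compound 2 by 4-cyanophenyl in place of 3-chlorophenyl on a saturated ring carbon. Among the compounds with values here, no measured step exchanges a chlorine for a nitrile, and the step from compound 1 to compound 3 bears on it only loosely; since every change seen so far left this assay flat, no movement beyond the scatter is expected. Compound 4 is therefore estimated at 85000 nM, within 40000 nM to 180000 nM, a step of a 1.1-fold higher number from compound 2 to compound 4 (0.04 log units; within the scatter) expected to stay within the scatter.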

Compound 4, half-maximal inhibitory concentration: 88700 nM
Compound 4: middle estimate off by 1.0-fold (0.02 log units), on the low side; the measured number falls inside the stated range.
By their numbers in this assay, from the lowest: compounds 2, 4, 1 and 3 (each within the scatter of the next).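

Placing 4-cyanophenyl instead of 3-chlorophenyl on this saturated ring carbon, next to the ring sulfur, adds a nitrile, yet this assay stays flat (a 1.1-fold higher number from compound 2 to compound 4 (0.06 log units; within the scatter)). On the aromatic carbon, cyano in place of phenyl (a 1.1-fold lower number from compound 3 to compound 4 (0.04 log units; within the scatter)) and cyano in place of nitro (a 1.0-fold lower number from compound 1 to compound 4 (0.01 log units; within the scatter)) also stay within the scatter, so all four compounds remain level. Nothing available explains this flatness.

As far as these compounds go, whether an amine or a carboxylic acid on the aromatic ring would move the number stays open. So does the part played by the vinylcarbonyl group.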